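The compounds below may be only part of what the source reports. "The series", "measured", "known", "first", "only" and "open" are said of these compounds alone.

Compound 1 `COc1ccc2nc(C)cc(OCC(=O)Nc3cc(C)cc(C)c3)c2c1` is one of three compounds tested in an ADME assay on blood (Mus musculus, strain CD1) for pharmacokinetics, read by LC-MS, with a stated time of 240 min, tested at 0.5 uM; on this read-out lower numbers stand for a shorter-lived compound and higher numbers for a longer-lived compound. In this assay compound 1 gives < 0.0834 h, which is a limit of the assay and not a number. Compound 2 `Cc1cc(C)cc(NC(=O)COc2cc(C)nc3ccc(C)cc23)c1` likewise gives < 0.0834 h in this assay, again a limit. The step that the two limits leave unreadable from compound 1 to compound 2 therefore cannot be sized, because the limit of < 0.0834 h in this assay, at which 2 of the 3 values shown sit, covers both ends of it. Within the data shown here, compound 3 `COc1ccc2nc(C)cc(OC(C)(C)C(=O)Nc3cc(C)cc(C)c3)c2c1` is the only one of the three with a number: in this assay compound 3 gives 1.6 h, but no single-point step connects it to compound 1.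

Compound 4 `COc1ccc2nc(C)cc(OCC(=O)Nc3cccc(C)c3)c2c1` differs from compound 1 by hydrogen in place of methyl on an aromatic carbon. Among the measured compounds shown here, no measured step touches this change, and the only step that shares compound 1 is the unreadable one from compound 1 to compound 2. What is known is therefore that compound 1 sits at the limit. For the measured compounds named here, with no step in hand to move it, compound 4 is expected to stay close to that limit, with a step that the limit leaves unreadable from compound 1 to compound 4 as the expected step; the estimate for compound 4 in this assay is 0.06 h, in the range from 0.02 h to 0.2 h.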

Compound 4, half-life: < 0.0834 h
Compound 4: a limit, no number; the forecaster's own chance of this, stated with the estimate: 75%; the middle value does not contradict the limit.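

In this assay, among these compounds, compound 1 and compound 4 both end in a limit of the assay and not a number, so no step between them can be read: the limit of < 0.0834 h in this assay, at which 3 of the 4 values shown sit. The compounds shown leave open whether hydrogen in place of methyl on an aromatic carbon changes the half-life at all.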